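Hydroxyalkyl Extension on the Pyrazole of Compound 3

The source may hold more compounds than are shown below. What is called first, only, known or untested is meant among the compounds shown, and "the series" means these compounds.

Measured compounds:
- Compound 1, `Cc1ccc(C(=O)Nc2cccc(CN3CCN(C)CC3)c2)cc1-c1ccc2cn[nH]c2c1`: 75.9 nM
- Compound 2, `Cc1ccc(C(=O)Nc2cc(CN3CCN(C4CCCC4)CC3)cc(C(F)(F)F)c2)cc1-c1ccc2cn[nH]c2c1`: 7 nM
- Compound 3, `Cc1ccc(C(=O)Nc2cccc(C(F)(F)F)c2)cc1-c1ccc2c(-c3cnn(C)c3)n[nH]c2c1`: 4.4 nM

All three share an amide linked to a bicyclic core. In an assay on isolated protein for inhibition of Discoidin domain-containing receptor 2 (Homo sapiens), read by ELISA, with a stated time of 60 min (on this read-out lower numbers stand for stronger inhibition and higher numbers for weaker inhibition), compound 3 gives the lowest number of the three. Its nearest neighbour is compound 2, and the gap between them lies within the usual scatter, so neither can be called more potent than the other. The gap to compound 1 is beyond the scatter, so compound 3 clearly inhibits more strongly than compound 1.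

Compound 4, `Cc1ccc(C(=O)Nc2cccc(C(F)(F)F)c2)cc1-c1ccc2c(-c3cnn(CC(C)O)c3)n[nH]c2c1`, has not yet been measured. It differs from compound 3 by 1-hydroxyethyl in place of hydrogen on a saturated chain carbon bound to an aromatic nitrogen. Among the compounds with values here, no directly comparable step is available among the measured compounds, so the effect of this change has to be estimated rather than read off. The change is small, and on that basis the step from compound 3 to compound 4 is expected to stay within the scatter, in either direction, as a 1.1-fold higher number from compound 3 to compound 4 (0.06 log units; within the scatter). Compound 4 is therefore expected to give 5 nM in this assay, with a plausible range from 1.5 nM to 16 nM.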

Compound 4, half-maximal inhibitory concentration: 3.7 nM
The estimate for compound 4 lay 1.4-fold (0.13 log units) above the measured number, within the range that was stated.
By their numbers in this assay, from the lowest: compounds 4, 3 and 2 (each within the scatter of the next); then compound 1.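

In this assay the change from methyl to 2-hydroxypropyl on the pyrazole gives a 1.2-fold lower number from compound 3 to compound 4 (0.08 log units; within the scatter) and so leaves compound 3 and compound 4 indistinguishable. Within the data shown here, this position, a saturated chain carbon bound to an aromatic nitrogen, therefore accepts 1-hydroxyethyl, with its 3 heavy atoms, hydrogen-bond donor and hydrogen-bond acceptor, without a measurable loss of inhibition, a single-place comparison that no earlier pair of compounds offered. Nothing measured here explains why the number holds steady.

A plain propyl chain in place of 2-hydroxypropyl would show whether the hydroxyl group itself matters to this result. As far as these compounds go, how far the position's tolerance extends also remains open, since an amine, a carboxylic acid or a longer chain could each give a different number.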